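A few compounds are considered here, and "the series" means these few. Any claim that something is new, unique, unknown or untested is made for them only; others in the source may bear on it.

In a functional assay on HCT-116 cells (Homo sapiens) for antiproliferative activity, read by MTT assay, with a stated time of 72 h; on this read-out lower numbers stand for stronger inhibition and higher numbers for weaker inhibition:

- compound 1 `NC1=NC2(CCSCC2)N(OCCCOc2ccc(Cl)c(Cl)c2)C(N)=N1`: 1 nM
- compound 2 `NC1=NC2(CCOCC2)N(OCCCOc2ccccc2)C(N)=N1`: 6010 nM

Of these two, compound 1 has the lower number, and the gap to compound 2 lies well beyond the scatter. Compound 3 `NC1=NC2(CCSCC2)N(OCCCOc2cc(Cl)c(Cl)cc2Cl)C(N)=N1` differs from compound 1 by chloro in place of hydrogen on an aromatic carbon, with chloro in place of hydrogen on an aromatic carbon. Within the data shown here, no measured pair shows this change, so the expectation is loose. As compound 1 already stands at 1 nM, a modest rise toward weaker inhibition seems likelier than a fall, and the expected step is a 4.0-fold higher number from compound 1 to compound 3 (0.60 log units; beyond the scatter). For compound 3, the estimated value in this assay is 4 nM, within an expected range of 0.6 nM to 30 nM.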

Compound 3, half-maximal inhibitory concentration: 1 nM
Beside the measured number, compound 3's estimate is 4.0-fold (0.60 log units) above it, within the range that was stated.
By their numbers in this assay, from the lowest: compounds 1 and 3 (each within the scatter of the next); then compound 2.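

In this assay, replacing hydrogen with chloro on the aromatic carbon ortho to a large group, which turns 3,4-dichlorophenyl into 2,4,5-trichlorophenyl, gives no change at the digits printed from compound 1 to compound 3 (within the scatter). Among these compounds, this is the first single-place step, and it shows that this position accepts a chloro group without a change beyond the scatter. No measurement shown explains this outcome. Going by these compounds, whether a methoxy group, an amine or a carboxylic acid would be accepted at this position remains open. So does whether the chloro group would give the same result on a different core.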